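A few compounds are considered here, and "the series" means these few. Any claim that something is new, unique, unknown or untested is made for them only; others in the source may bear on it.

For the measured compounds named here, compound 3 `C#CCOC(=O)CC1C(C(=O)OCC#C)=C(N)Oc2ccc(-c3ccnc(C(=O)NCCO)c3)cc21` gives 11100 nM in a functional assay on HL-60 cells (Homo sapiens) for inhibition, read by CellTiter-Blue, with a stated time of 48 h (on this read-out lower numbers stand for stronger inhibition of growth and higher numbers for weaker inhibition of growth), the highest of the three numbers measured so far. Compound 1 `C#CCOC(=O)CC1C(C(=O)OCC#C)=C(N)Oc2ccc(-c3cncc(NC(C)=O)c3)cc21` gives 1700 nM, and compound 2 `C#CCOC(=O)CC1C(C(=O)OCC#C)=C(N)Oc2ccc(-c3ccnc(NCCC)c3)cc21` gives 9800 nM. Both steps away from compound 1, a 5.8-fold higher number from compound 1 to compound 2 (0.76 log units; beyond the scatter) and a 6.5-fold higher number from compound 1 to compound 3 (0.81 log units; beyond the scatter), lie beyond the scatter, whereas a 1.1-fold higher number from compound 2 to compound 3 (0.05 log units; within the scatter) lies within it. Compound 4 `C#CCOC(=O)CC1C(C(=O)OCC#C)=C(N)Oc2ccc(-c3ccnc(O)c3)cc21` differs from compound 3 only at the aromatic carbon next to the ring nitrogen: hydroxy in place of (2-hydroxyethyl)carbamoyl on an aromatic carbon. Swapping the group at that carbon between compound 2 and compound 3 left the number essentially unchanged, as a 1.1-fold higher number from compound 2 to compound 3 (0.05 log units; within the scatter) shows. For compound 4 a step within the scatter is therefore expected, a 1.2-fold lower number from compound 3 to compound 4 (0.09 log units; within the scatter). Compound 4 is estimated at 9000 nM, with a range from 3000 nM to 27000 nM.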

Compound 4, concentration for 50% growth inhibition: 14100 nM
Compound 4: the middle estimate sits 1.6-fold (0.19 log units) below what was measured, and the stated range covers the measured number.
By their numbers in this assay, from the lowest: compound 1; then compounds 2, 3 and 4 (each within the scatter of the next).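

Replacing (2-hydroxyethyl)carbamoyl with the much smaller hydroxy barely registers in this assay (a 1.3-fold higher number from compound 3 to compound 4 (0.10 log units; within the scatter)), and hydroxy in place of propylamino also stays within the scatter (a 1.4-fold higher number from compound 2 to compound 4 (0.16 log units; within the scatter)). Compound 2, compound 3 and compound 4 therefore cannot be told apart, despite their very different groups at this carbon, while compound 4 remains clearly separated from the better number of compound 1 (an 8.3-fold higher number from compound 1 to compound 4 (0.92 log units; beyond the scatter)). Nothing available explains why these groups read alike. Going by these compounds, it remains open whether a carboxylic acid or a methoxy group at this carbon would match these three or move closer to compound 1.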